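Halogen position on the pendant phenyl: cytotoxicity notes

A few compounds are considered here, and "the series" means these few. Any claim that something is new, unique, unknown or untested is made for them only; others in the source may bear on it.

Measured compounds:
compound 1 `O=C1CSC(c2cccc(F)c2)N1CCN1CCCCC1` with 27%
compound 2 `O=C1CSC(c2ccc(Cl)cc2)N1CCN1CCCCC1` with 15%
compound 3 `O=C1CSC(c2ccc(F)cc2)N1CCN1CCCCC1` with 17%

All three share one core and differ only in the aryl group on the saturated ring carbon. In an ADME assay on Vero cells (Chlorocebus sabaeus) for cytotoxicity, read by neutral red uptake, tested at 787 ug/mL (on this read-out lower numbers stand for a stronger effect and higher numbers for a weaker effect at the one concentration tested), compound 3 cannot be set apart from either of the others: a number 10 percentage points lower from compound 1 to compound 3 (within the scatter) and a number 2 percentage points higher from compound 2 to compound 3 (within the scatter). For the measured compounds named here, the only step that clears the scatter is a number 12 percentage points lower from compound 1 to compound 2 (beyond the scatter), and even that is modest.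

Compound 4 is `O=C1CSC(c2ccccc2Cl)N1CCN1CCCCC1`. Compared with compound 3 the change is 2-chlorophenyl in place of 4-fluorophenyl on a saturated ring carbon. Going by the values given here, two measured steps bear on it. The exchange of fluoro for chloro on the aromatic ring gave a number 2 percentage points higher from compound 2 to compound 3 (within the scatter); moving the halogen from the 3- to the 4-position gave a number 10 percentage points lower from compound 1 to compound 3 (within the scatter). Among the compounds with values here, no measured step puts a halogen at the 2-position, so that part of the change has no direct precedent. Because the related steps of a number 2 percentage points higher from compound 2 to compound 3 (within the scatter) and a number 10 percentage points lower from compound 1 to compound 3 (within the scatter) both stay within the scatter, compound 4 is expected to show a number 3 percentage points higher from compound 3 to compound 4 (within the scatter), no step beyond the scatter. Compound 4 is therefore estimated at 20%, with a range from 8% to 34%.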

Compound 4, a percentage reported as activity, at one concentration (the size of the read-out at that concentration, not a potency): 38%
Estimate against measurement, compound 4: 18 percentage points below; measured number outside the range, above it.
By their numbers in this assay, from the lowest: compounds 2, 3 and 1 (each within the scatter of the next, the first and the last beyond it); then compound 4.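

In this assay compound 4 separates from every earlier compound, with a number 21 percentage points higher from compound 3 to compound 4 (beyond the scatter) and a number 11 percentage points higher from compound 1 to compound 4 (beyond the scatter), so 2-chlorophenyl on the saturated ring carbon gives the weakest effect of the four at the one concentration tested. The most direct comparison keeps chlorine and changes only its place on the phenyl, giving a number 23 percentage points higher from compound 2 to compound 4 (beyond the scatter), so halogen placement can shift this read-out beyond the scatter, whereas the exchange of chloro for fluoro in the 4-substituted pair did not. No measurement shown accounts for this shift.

Going by these compounds, whether the shift belongs to chlorine or to any group at that place stays open, as the 2-position carries only chloro here. Methoxy, an amine or a carboxylic acid on the phenyl also remains untested in the compounds shown.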